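The source may hold more compounds than are shown below. What is called first, only, known or untested is meant among the compounds shown, and "the series" means these compounds.

Three compounds share one saturated ring with four stereocentres and differ only in how those centres are drawn. Compound 1 `O=C(O)[C@@H]1NC[C@@H](O)[C@@H](O)[C@H]1O` gives 8.2% in an assay for inhibition of alpha-N-acetylgalactosaminidase (Gallus gallus), tested at 1000 uM; a lower number here means less inhibition, a higher number more inhibition at the concentration tested (going by the name of the read-out). Compound 2 `O=C(O)[C@@H]1NC[C@@H](O)[C@@H](O)[C@@H]1O` gives 7.2% in the same assay, and compound 3 `O=C(O)[C@@H]1NC[C@H](O)[C@H](O)[C@H]1O` gives 4.4%. On the numbers shown, compound 3 sits at the low end of the three, but the steps leading to it, a number 3.8 percentage points lower from compound 1 to compound 3 (within the scatter) and a number 2.8 percentage points lower from compound 2 to compound 3 (within the scatter), both stay within the scatter, as does a number 1 percentage points lower from compound 1 to compound 2 (within the scatter). Each of these steps is a pure change of configuration the fact that compounds 1 and 2 differ only in the configuration as drawn the fact that compounds 1 and 3 differ only in the configuration as drawn (the fact that compounds 2 and 3 differ only in the configuration as drawn), and none of them moved the read-out beyond what repeated measurement would give.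

Compound 4 `O=C(O)[C@@H]1NC[C@H](O)[C@@H](O)[C@H]1O` has not yet been measured. Its relation to compound 3 is the two compounds have the same atoms and bonds and differ only in configuration as drawn: 1 of 4 stereo elements differ; a stereocentre at a saturated ring carbon is drawn S in compound 3 and R in compound 4. All three measured steps bear on this change, since each also turned one or more stereocentres without touching atoms or bonds, and each came out within the scatter. The expectation for compound 4 in this assay is therefore no step beyond the scatter, in either direction. The estimated step is a number 1.6 percentage points higher from compound 3 to compound 4 (within the scatter). Compound 4 is estimated at 6%, with a range from 0% to 13%.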

Compound 4, a percentage reported as inhibition, at one concentration (the size of the read-out at that concentration, not a potency): 4%
Beside the measured number, compound 4's estimate is 2 percentage points above it, within the range that was stated.
By their numbers in this assay, from the lowest: compounds 4, 3, 2 and 1 (each within the scatter of the next).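

In this assay, turning this one stereocentre from S to R gives a number 0.4 percentage points lower from compound 3 to compound 4 (within the scatter), so at this ring carbon the change leaves the read-out within the scatter. Compound 4 also adds a single-centre step at a different ring carbon, a number 4.2 percentage points lower from compound 1 to compound 4 (within the scatter), and a two-centre step, a number 3.2 percentage points lower from compound 2 to compound 4 (within the scatter), and neither of these leaves the scatter either, so none of the four configurations separates from another in this assay. Nothing entered or left the structure in the change at this position, which means the step speaks to configuration alone: the fact that compounds 3 and 4 differ only in the configuration as drawn

With every step this small and only one concentration tested, the compounds shown cannot tell which stereocentres, if any, matter for this enzyme, and the configurations outside these four remain open. They also leave open whether a methyl ester or an amide in place of the carboxylic acid, or a longer chain on the shared core, would move the read-out beyond the scatter.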